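Dichlorophenyl Sulfone at the Core: Compound 4 Awaits Measurement

The source may report more compounds than this note shows. Statements on the series, on what has been measured and on what is new or still open speak of the compounds shown alone.

Compound 1 `CC1CCN(c2c(S(=O)(=O)c3ccc(C#N)cc3)cnc3cc(Cl)ccc23)CC1`: 70%
Compound 2 `CC1CCN(c2c(S(=O)(=O)c3ccc(C#N)cc3)cnc3cc(F)ccc23)CC1`: 83%
Compound 3 `CC1CCN(c2c(S(=O)(=O)c3cccc(Cl)c3)cnc3ccc(F)cc23)CC1`: 92%

In an assay on isolated protein for displacement of a labelled ligand from metabotropic glutamate receptor 5 (Homo sapiens), with a stated time of 60 min, tested at 1 uM (a higher number here means more inhibition at the concentration tested (going by the name of the read-out), a lower number less inhibition), compound 1 gives 70%, the lowest of the three numbers; compound 2 lies a number 13 percentage points higher from compound 1 to compound 2 (beyond the scatter), and compound 3, which differs in more than one place, stands higher still. Compound 4 `CC1CCN(c2c(S(=O)(=O)c3cc(Cl)cc(Cl)c3)cnc3cc(Cl)ccc23)CC1` departs from compound 1 by 3,5-dichlorophenyl in place of 4-cyanophenyl on a sulfonyl sulfur. For the measured compounds named here, the one measured step, fluoro in place of chloro on the core, does not touch the sulfonyl substituent, so no measured step bears directly on this change. Compound 3, carrying a chlorophenyl on the sulfonyl sulfur, reaches 92%, but its core also differs, so only weak guidance follows. Compound 4 is therefore expected to give about 76%, within 55% to 95%, a step of a number 6 percentage points higher from compound 1 to compound 4 (within the scatter) that is estimated to stay near the scatter.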

Compound 4, a percentage reported as inhibition, at one concentration (the size of the read-out at that concentration, not a potency): 93%
For compound 4 the middle estimate is 17 percentage points below the measured one; low and high end bracket the measured number.
By their numbers in this assay, from the lowest: compound 1; then compounds 2, 3 and 4 (each within the scatter of the next).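

In this assay, for the compounds shown here, the change to 3,5-dichlorophenyl in place of 4-cyanophenyl on a sulfonyl sulfur gives a number 23 percentage points higher from compound 1 to compound 4 (beyond the scatter) and so provides the first reading at this place with the rest of compound 1 held constant. The earlier single step touched only the core, so the sulfonyl substituent now joins the core as a place where the number moves beyond the scatter. No measurement shown here explains this rise.

On these data alone, whether it comes from the two chlorines entering or from the nitrile leaving stays open. So does the effect of a methoxy group or an amine on that phenyl ring.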